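Benzyloxy Ring Substituent Swap in an Antiproliferative Series

A few compounds are considered here, and "the series" means these few. Any claim that something is new, unique, unknown or untested is made for them only; others in the source may bear on it.

Compound 1, `Cc1cccc(COc2ccc(-c3cc(CN4CCN(Cc5ccc(C(F)(F)F)cc5)CC4)no3)cc2)c1`: 2500 nM
Compound 2, `FC(F)(F)c1ccc(CN2CCN(Cc3cc(-c4ccc(OCc5ccccc5Cl)cc4)on3)CC2)cc1`: 3200 nM

In a functional assay on Mahlavu cells (Homo sapiens) for antiproliferative activity, read by sulforhodamine B assay, with a stated time of 72 h (on this read-out higher numbers stand for weaker inhibition and lower numbers for stronger inhibition), compound 2 gives 3200 nM, and in this assay compound 1 gives 2500 nM. Compound 2 has the higher of the two numbers, and its nearest neighbour is compound 1; the step of a 1.3-fold higher number from compound 1 to compound 2 (0.11 log units; within the scatter) is within the scatter, so the two compounds cannot be told apart on these data.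

Compound 3, `Fc1cccc(COc2ccc(-c3cc(CN4CCN(Cc5ccc(C(F)(F)F)cc5)CC4)no3)cc2)c1`, has not yet been measured in this assay. It differs from compound 2 by 3-fluorophenyl in place of 2-chlorophenyl on a saturated chain carbon bound to an oxygen on an aromatic ring. Among the compounds with values here, the one measured step that bears on this position, a 1.3-fold higher number from compound 1 to compound 2 (0.11 log units; within the scatter), also exchanged the ring on that saturated chain carbon and stayed within the scatter. Nothing else among the measured compounds touches this part of the molecule.

On that basis a step of a 1.1-fold lower number from compound 2 to compound 3 (0.06 log units; within the scatter) is expected, that is, no change beyond the scatter. Compound 3 is therefore estimated at 2800 nM in this assay, with a range from 1400 nM to 6000 nM.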

Compound 3, half-maximal inhibitory concentration: 2900 nM
Compound 3: the middle estimate sits 1.0-fold (0.02 log units) below what was measured; the range from low to high includes it.
By their numbers in this assay, from the lowest: compounds 1, 3 and 2 (each within the scatter of the next).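

In this assay, 3-fluorophenyl in place of 2-chlorophenyl on the saturated chain carbon bound to an oxygen on an aromatic ring gives a 1.1-fold lower number from compound 2 to compound 3 (0.04 log units; within the scatter), so a third ring at this position can't be told apart from the first two. The new compound also adds a comparison that the earlier pair did not offer, a change of substituent alone: fluoro in place of methyl on an aromatic carbon gives a 1.2-fold higher number from compound 1 to compound 3 (0.06 log units; within the scatter), which again shows no readable difference. Across the methyl, chloro and fluoro variants shown here, this position therefore shows no measurable preference, and no supporting data are available to interpret that flat result.

The compounds shown leave open whether a more different group on this ring, such as an amine, a carboxylic acid or a nitrile, or a longer chain in place of the benzyl link, would move the number beyond the scatter. As far as these compounds go, the trifluoromethyl group and the shared core are the same in all three compounds, so how the activity responds to changes in those parts also remains open.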